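Dimethylamino in place of amino at the five-membered ring

A few compounds are considered here, and "the series" means these few. Any claim that something is new, unique, unknown or untested is made for them only; others in the source may bear on it.

The series shares one core carrying a (2-hydroxyethoxy)methyl group, and the three measured compounds differ only in the substituent on an aromatic carbon of the five-membered ring. Compound 1 `Nc1nc2c(nc(Br)n2COCCO)c(=O)[nH]1` bears a bromo group; in a functional assay on L1210 cells (Mus musculus) for inhibition (on this read-out lower numbers stand for stronger inhibition and higher numbers for weaker inhibition), compound 1 gives 355 ug/mL. Compound 2 `Nc1nc2c(nc(O)n2COCCO)c(=O)[nH]1` carries a hydroxy group there. For compound 2 the read-out is a limit of the assay, > 500 ug/mL, not a number. Compound 3 `Nc1nc2c(nc(N)n2COCCO)c(=O)[nH]1` carries an amino group. For compound 3 the read-out is likewise a limit, > 500 ug/mL, and not a number. Thus compound 3 stands at the limit of > 500 ug/mL in this assay, at which 2 of the 3 values shown sit, which is the same limit that compound 2 reaches, and the two cannot be ordered. The steps of an at least 1.4-fold higher number from compound 1 to compound 2 (0.14 log units; that floor lies within the scatter) and an at least 1.4-fold higher number from compound 1 to compound 3 (0.14 log units; that floor lies within the scatter) have floors within the scatter, while a step that the two limits leave unreadable from compound 2 to compound 3.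

Compound 4 `CN(C)c1nc2c(=O)[nH]c(N)nc2n1COCCO` differs from compound 3 by dimethylamino in place of amino on an aromatic carbon. Going by the values given here, no measured step changes amino to dimethylamino, so the only bearing evidence is that compound 3 sits at the limit. Compound 4 is therefore expected to remain weak, with an estimated 500 ug/mL spanning 200 ug/mL to 1200 ug/mL. This estimate means a number no higher from compound 3 to compound 4 (the limit leaves the size open), expected to lie within the scatter.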

Compound 4, concentration for 50% inhibition: > 500 ug/mL
Compound 4 ended at the assay's limit; the forecaster's own chance of this, stated with the estimate: 60%; the middle value sits exactly at the limit.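

In this assay the read-out of compound 4 is a limit and not a number, so swapping amino for dimethylamino, which adds heavy atoms and gives up the hydrogen-bond donor, brought no readable value at this position, and the steps from compound 3 to compound 4 and from compound 2 to compound 4 cannot be read. The one step that can be read is an at least 1.4-fold higher number from compound 1 to compound 4 (0.14 log units; that floor lies within the scatter), so compound 4 is not shown to differ beyond the scatter from compound 1, with its bromo group. The position now carries hydroxy in compound 2, amino in compound 3 and dimethylamino in compound 4, all ending at the same limit, while only bromo in compound 1 goes against this by giving a number: the limit of > 500 ug/mL in this assay, at which 3 of the 4 values shown sit.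

What the compounds shown leave open is how far compound 2, compound 3 and compound 4 lie past the limit, and so whether dimethylamino changes anything relative to amino at all. They also leave open whether another halogen such as chloro or iodo, or a longer chain such as diethylamino, would give a number at this position.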